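The source may report more compounds than this note shows. Statements on the series, on what has been measured and on what is new or still open speak of the compounds shown alone.

In an ADME assay on RAW264.7 cells (Mus musculus) for cytotoxicity, read by MTT assay, with a stated time of 24 h, in the presence of a further agent that is not named here (on this read-out higher numbers stand for weaker inhibition and lower numbers for stronger inhibition), compound 1 (`O=C1OC(Cc2nc(-c3ccccc3)no2)c2ccccc21`) gives > 40000 nM as a limit. Compound 2 (`COc1cc(OC)c2c(c1)C(C(O)c1ccc(O)cc1)OC2=O`) gives > 40000 nM as a limit. Compound 3 (`CCOc1ccc(C(O)C2OC(=O)c3c(OC)cc(OC)cc32)cc1`) gives > 40000 nM as a limit too, so it stands with the others at the limit of > 40000 nM in this assay, at which 3 of the 3 values shown sit, and has no number of its own. Compound 4 (`CCCCCCOc1ccc(C(O)C2OC(=O)c3c(OC)cc(OC)cc32)cc1`) differs from it by butyl in place of hydrogen on a saturated chain carbon, two bonds along the chain from an oxygen on an aromatic ring and so turns ethoxy to hexyloxy. Going by the values given here, the one measured step that bears on this change, a step that the two limits leave unreadable from compound 2 to compound 3, has no readable size and gives no direction. No step beyond the scatter is therefore expected, and another limit is the likeliest report. The estimated a number no higher from compound 3 to compound 4 (the limit leaves the size open) in this assay is only a working figure. For compound 4 the expected value is 40000 nM with an estimated range of 15000 nM to 80000 nM in this assay for now.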

Compound 4, half-maximal inhibitory concentration: > 40000 nM
Compound 4: a limit, no number (the forecaster's own chance of this, stated with the estimate: 75%); the middle value sits exactly at the limit.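

No step can be read among compound 2, compound 3 and compound 4 in this assay, because each value is a limit and not a number: the limit of > 40000 nM in this assay, at which 4 of the 4 values shown sit.

The compounds shown leave open whether going from ethoxy to hexyloxy changes anything in this assay.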